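Ring-nitrogen substituent: dimethoxyphenyl in place of isoxazole

A few compounds are considered here, and "the series" means these few. Any claim that something is new, unique, unknown or untested is made for them only; others in the source may bear on it.

Measured so far:
compound 1 `CC1SC(c2cccc(C(=O)NCCCCc3ccccc3)c2)N(c2ccc(C3CC3)cc2)C1=O`: 191 nM
compound 2 `CC(C)(C)c1conc1N1C(=O)CSC1c1cccc(C(=O)NCCCCc2ccccc2)c1`: > 1000 nM
compound 3 `O=C(NCCCCn1cccn1)c1cccc(C2SCC(=O)N2c2ccccn2)c1`: 60.3 nM

In a functional assay on HOS-TE85 cells (Homo sapiens) for inhibition, read by CCK-8 assay, with a stated time of 72 h (a lower number here means a stronger inhibitor, a higher number a weaker inhibitor), compound 1 gives 191 nM and compound 3 gives 60.3 nM. For compound 2 only a limit of the assay is known, > 1000 nM. Compound 2 therefore stands at the limit of > 1000 nM in this assay, at which 1 of the 3 values shown sits, the weak end of the three.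

Compound 4 `COc1cccc(OC)c1N1C(=O)CSC1c1cccc(C(=O)NCCCCc2ccccc2)c1` awaits measurement. It differs from compound 2 by a group of 10 heavy atoms (8 carbon, 2 oxygen; one six-membered aromatic ring of carbon only) in place of a group of 9 heavy atoms (7 carbon, 1 nitrogen, 1 oxygen; one five-membered aromatic ring with 2 hetero atoms), on an amide-type nitrogen in a ring.

Compound 1 and compound 3 each give a number in this assay, while compound 2 gives only the limit. A step toward a stronger inhibitor, beyond the usual scatter, is expected for compound 4, estimated as an at least 3.3-fold lower number from compound 2 to compound 4 (0.52 log units; beyond the scatter). Compound 4 is expected at 300 nM, with a range from 100 nM to 1500 nM.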

Compound 4, half-maximal inhibitory concentration: > 1000 nM
Compound 4 gave a limit, no number; the forecaster's own chance of this, stated with the estimate: 25%; at least 3.3-fold (0.52 log units) between middle value and limit.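

Compound 2 and compound 4 both give only limits, so no step between them can be read: the limit of > 1000 nM in this assay, at which 2 of the 4 values shown sit.

Left open is how the 2,6-dimethoxyphenyl group of compound 4 compares in strength with the group it replaces in compound 2.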